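The source may hold more compounds than are shown below. What is called first, only, known or untested is meant among the compounds shown, and "the series" means these compounds.

Three compounds have been measured in a physicochemical assay for lipophilicity, read by HPLC, measured as octanol-water partition, at pH 7.4; a higher number here means a more lipophilic compound, a lower number a more polar compound:

Compound 1 `CCN1CCC2(CC1)CC(=O)c1ccc3ccccc3c1O2` gives 2.19 in this assay.
Compound 2 `c1ccc2c3c(ccc2c1)CCC1(CCNCC1)O3` gives 2.33 in this assay.
Compound 3 `O=C1CC2(CCNCC2)Oc2c1ccc1ccccc21` gives 1.78 in this assay.

Compound 3 and compound 1 differ in one place, (ethyl in place of hydrogen on an amine nitrogen in a ring), and this change brings a number 0.41 log units higher from compound 3 to compound 1 (beyond the scatter). Compound 2 has the highest of the three numbers, though its gap to compound 1 lies within the scatter. The difference between the core of compound 2 and the core of compound 3 is not broken down here.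

Compound 4 `CCN1CCC2(CCc3ccc4ccccc4c3O2)CC1` is not yet measured. It differs from compound 2 by ethyl in place of hydrogen on an amine nitrogen in a ring, the same change as that from compound 3 to compound 1. In this assay the step is expected to be a number 0.41 log units higher from compound 2 to compound 4 (beyond the scatter), resting on the earlier step of a number 0.41 log units higher from compound 3 to compound 1 (beyond the scatter). Compound 4 is therefore estimated at 2.74, with a range from 2.4 to 3.1.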

Compound 4, distribution coefficient: 2.88
The estimate for compound 4 lay 0.14 log units below the measured number, within the range that was stated.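

Carried to the core of compound 2, ethyl in place of hydrogen on the amine nitrogen in a ring gives a number 0.55 log units higher from compound 2 to compound 4 (beyond the scatter) in this assay. This runs in the same direction as a number 0.41 log units higher from compound 3 to compound 1 (beyond the scatter), so the change raises the number on both cores shown. Going by these compounds alone, two cores are only one pair, however, so this does not show that the step would carry to any other core, and nothing measured here bears on what lies behind it.

The compounds shown carry only hydrogen or ethyl on that nitrogen. As far as these compounds go, how a propyl group, or a longer chain ending in a carboxylic acid, would read in this assay remains open.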